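The compounds below may be only part of what the source reports. "The series", "measured", "known", "first", "only" and "open" are said of these compounds alone.

Measured so far in an ADME assay on HepG2 cells (Homo sapiens) for cytotoxicity, with a stated time of 72 h (a higher number here means that more compound is needed for the effect, a lower number that less compound is needed), are two compounds
- compound 1 (`CC(=O)c1ccc(NC(=O)Nc2cc(C)nc3ccccc23)cc1`) gives 19000 nM as a number
- compound 2 (`Cc1cc(NC(=O)Nc2ccccc2C(C)(C)C)c2ccccc2n1`) gives > 25000 nM as a limit of the assay

Going by the values given here, compound 1 holds the only true number so far, while compound 2 has only a limit. Compound 3 (`COC(=O)c1ccc(NC(=O)Nc2cc(C)nc3ccccc23)cc1`) differs from compound 1 in one place (methoxy in place of methyl on a carbonyl carbon) with methoxy in place of methyl on a carbonyl carbon. Among the compounds with values here, no measured step covers this change, so the expectation rests on compound 1 at 19000 nM alone. The change expected in this assay is none beyond the scatter (a 1.1-fold lower number from compound 1 to compound 3 (0.02 log units; within the scatter)) in either direction. For compound 3 the estimated value is 18000 nM (expected range 8000 nM to 25000 nM).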

Compound 3, half-maximal effective concentration: 20000 nM
Compound 3: the middle estimate sits 1.1-fold (0.05 log units) below what was measured, and the stated range covers the measured number.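

Acetyl to methoxycarbonyl is the first change in one place that can be read in this assay, and it gives a 1.1-fold higher number from compound 1 to compound 3 (0.02 log units; within the scatter). Methoxy in place of methyl on a carbonyl carbon therefore leaves the number within the scatter for this pair, even though a hydrogen-bond acceptor enters with the methoxy.

On these data alone, a carboxylic acid or an amine in this place remains open, and a single pair sets no trend. Compound 2 offers only a limit of the assay, not a number: the limit of > 25000 nM in this assay, at which 1 of the 3 values shown sits.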